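This account rests on a few compounds, and the source may have more. Where it says the series, first, only, none or still open, it means among the compounds named here.

Measured compounds:
Compound 1 `Cc1nc2c(OCc3ccccn3)cccn2c1N` gives 24% in a functional assay on the whole organism with Canis familiaris (Canis lupus familiaris) as the target, at a dose of 5 mg/kg by the intravenous route; a higher number here means a stronger effect of the compound at the dose given, a lower number a weaker effect.
Compound 2 `Cc1nc2c(OCc3ccccc3)cccn2c1CN` gives 49% in this assay.

Compound 2 holds the highest of the two numbers, and its nearest neighbour, compound 1, stands a full step lower, a gap that lies beyond the usual scatter of this assay. The two differ in more than one place, so no single change can be read from that gap.

Compound 3 `CNC(=O)Nc1c(C)nc2c(OCc3ccccc3)cccn12` has not yet been measured. It differs from compound 2 in one place: (methylcarbamoyl)amino in place of aminomethyl on an aromatic carbon. For the measured compounds named here, no measured pair shows this change on its own, so the size of the step has to be judged without a precedent. The step from compound 2 to compound 3, a number 9 percentage points lower from compound 2 to compound 3 (within the scatter), is expected to be modest in the downward direction and may well fall within the scatter. Compound 3 is therefore estimated at 40%, with a range from 15% to 70%.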

Compound 3, a percentage reported as inhibition, in the whole organism at one dose (the size of the read-out at that dose, not a potency): 27%
Estimate against measurement, compound 3: 13 percentage points above; the range from low to high includes it.
By their numbers in this assay, from the lowest: compounds 1 and 3 (each within the scatter of the next); then compound 2.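

In this assay, for the compounds shown here, the change from aminomethyl to (methylcarbamoyl)amino on the aromatic carbon of the five-membered ring is the first single change that can be read, and it gives a number 22 percentage points lower from compound 2 to compound 3 (beyond the scatter). This shows that the effect at the dose given depends on what this position carries, and that the (methylcarbamoyl)amino group does not match aminomethyl here. Nothing at hand explains the drop.

Going by these compounds alone, the single step cannot separate the parts of the entering group, so it remains unclear whether the carbonyl, the extra nitrogen or the terminal methyl accounts for it. Going by these compounds, it also remains open whether a longer chain such as aminoethyl, or a carboxylic acid, at this place would give a number nearer that of compound 2 or further from it.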